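The source may hold more compounds than are shown below. What is called first, only, known or untested is meant among the compounds shown, and "the series" means these compounds.

Measured so far:
compound 1 `COc1cccc(CN2CC=C(CCC(=O)NO)C2=O)c1`: 1770 nM
compound 2 `COc1cccc(CCCN2CC=C(CCC(=O)NO)C2=O)c1`: 1880 nM

Both numbers come from a functional assay on MDA-MB-231 cells (Homo sapiens) for antiproliferative activity; on this read-out higher numbers stand for weaker inhibition of growth and lower numbers for stronger inhibition of growth. Compound 1 and compound 2 give values that sit within the usual scatter of each other, so neither can be called the stronger inhibitor of growth. Compound 3 `O=C(CCC1=CCN(Cc2ccccc2)C1=O)NO` has not been measured in this assay. It differs from compound 1 by hydrogen in place of methoxy on an aromatic carbon, meta to a large group. For the measured compounds named here, no measured pair shows what this change does here, so only a small step is expected in this assay, if any beyond the scatter, perhaps toward weaker inhibition of growth. Compound 3 is therefore expected to give about 2500 nM, between 1000 nM and 6500 nM. That estimate means an expected step of a 1.4-fold higher number from compound 1 to compound 3 (0.15 log units; within the scatter).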

Compound 3, concentration for 50% growth inhibition: 990 nM
The estimate for compound 3 lay 2.5-fold (0.40 log units) above the measured number, outside the stated range (below it).
By their numbers in this assay, from the lowest: compounds 3, 1 and 2 (each within the scatter of the next).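

Hydrogen in place of methoxy on this aromatic carbon, meta to a large group, gives a 1.8-fold lower number from compound 1 to compound 3 (0.25 log units; within the scatter) in this assay and so leaves the two compounds indistinguishable on this read-out. In this pair, the methoxy group is not needed for growth inhibition at this level. Nothing shown here explains the result.

Going by these compounds, whether an amine or a carboxylic acid on this carbon would give a step beyond the scatter remains open. So does whether hydrogen in place of methoxy would give a similar result in compound 2, with its longer chain.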